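Removing a Methoxy Group: Expected Effect on Macrophage Cytotoxicity

The source may hold more compounds than are shown below. What is called first, only, known or untested is meant among the compounds shown, and "the series" means these compounds.

Measured compounds:
Compound 1 `COc1ccc(C(=O)Nc2ccc(Cl)cc2F)cc1`: in an ADME assay on RAW264.7 cells (Mus musculus) for cytotoxicity, read by MTT assay, with a stated time of 24 h (on this read-out higher numbers stand for lower toxicity in this test and lower numbers for higher toxicity in this test), compound 1 gives > 40000 nM, a limit of the assay rather than a number.
Compound 2 `COc1ccc(C(=O)Nc2ccc(I)cc2F)c(O)c1`: in this assay compound 2 gives 27600 nM.
Compound 3 `COc1ccc(C(=O)Nc2ccc(I)cc2F)c(OC)c1`: in this assay compound 3 gives > 40000 nM, again a limit of the assay.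

Compound 3 therefore stands at the edge of what the assay reports; the limit of > 40000 nM in this assay, at which 2 of the 3 values shown sit, shows that compound 1 sits there as well. Compound 4 `COc1ccc(C(=O)Nc2ccc(I)cc2F)cc1` differs from compound 3 by hydrogen in place of methoxy on an aromatic carbon. For the measured compounds named here, the only measured step touching this part of the shared core is an at least 1.4-fold higher number from compound 2 to compound 3 (0.16 log units; that floor lies within the scatter), whose lower bound lies within the scatter. Going by the values given here, no measured step removes the methoxy group outright, so no change beyond the scatter is expected in this assay. Compound 4 is estimated at 40000 nM, with a range from 20000 nM to 80000 nM. This corresponds to an expected step of a number no higher from compound 3 to compound 4 (the limit leaves the size open).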

Compound 4, half-maximal cytotoxic concentration: 32800 nM
For compound 4 the middle estimate is 1.2-fold (0.09 log units) above the measured one, and the stated range covers the measured number.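

Losing the methoxy group reads in this assay as an at least 1.2-fold lower number from compound 3 to compound 4 (0.08 log units; that floor lies within the scatter) while iodo in place of chloro reads as a second floor (an at least 1.2-fold lower number from compound 1 to compound 4 (0.08 log units; that floor lies within the scatter)). Neither step has a known full size, because each starts from a limit of the assay: the limit of > 40000 nM in this assay, at which 2 of the 4 values shown sit. For the compounds shown here, the one pair with two real numbers, hydroxy against hydrogen at this position, gives a 1.2-fold higher number from compound 2 to compound 4 (0.07 log units; within the scatter) and so shows no change beyond the scatter.

Going by these compounds, whether an amine or a carboxylic acid on this aromatic carbon would move the number beyond the scatter stays open.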